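Ring-expanded core: ketone to propylamide

The compounds below may be only part of what the source reports. "The series", "measured", "known", "first", "only" and "open" are said of these compounds alone.

Of the compounds shown here, two have been measured in an assay on SHEP1 cells for displacement of a labelled ligand from Neuronal acetylcholine receptor; alpha4/beta2 (Homo sapiens), read by scintillation counting, with a stated time of 2 h; a higher number here means a weaker inhibitor, a lower number a stronger inhibitor. Compound 1 `O=C(C1CC1)[C@H]1C[C@H]2CNC[C@H]2C1` gives 0.5 nM. Compound 2 `O=C(C1CC1)[C@H]1C[C@@H]2CNC[C@@H](C2)C1`, built on a larger bicyclic core, gives 43 nM, the highest of the two numbers, and the gap to compound 1 lies beyond the usual scatter of this assay. Among the measured compounds shown here, no single-site step between the measured compounds is available, so the effect of the core change alone cannot be separated from anything else.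

Compound 3 `CCCNC(=O)[C@H]1C[C@@H]2CNC[C@@H](C2)C1` keeps the core of compound 2 and alters the carbonyl substituent: propylamino in place of cyclopropyl on a carbonyl carbon. Nothing measured in the series speaks to this exchange, so the step has to be judged on the structural change alone. A ketone-to-amide exchange of this kind is expected to shift the number modestly upward, though a step within the scatter cannot be ruled out. The step from compound 2 to compound 3 is therefore estimated as a 2.8-fold higher number from compound 2 to compound 3 (0.45 log units; beyond the scatter). In this assay compound 3 is expected to give about 120 nM, with a plausible range from 25 nM to 600 nM.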

Compound 3, inhibition constant: 6 nM
The estimate for compound 3 lay 20-fold (1.30 log units) above the measured number; the whole stated range lies above it.
By their numbers in this assay, from the lowest: compound 1; then compound 3; then compound 2.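

Propylamino in place of cyclopropyl on a carbonyl carbon gives a 7.2-fold lower number from compound 2 to compound 3 (0.86 log units; beyond the scatter) in this assay, the first single-site step available in this series. The substituent on this carbonyl carbon therefore moves the number beyond the scatter on this core, and here the open-chain amide substituent, which brings a nitrogen and a hydrogen-bond donor, goes with the lower number, not the higher one. No supporting measurement accounts for the direction or size of this step.

The exchange changes two things at once, replacing the ring with an open chain and introducing the nitrogen, so a propyl ketone or a cyclopropylamino amide on the same core would be needed to tell these two contributions apart. Also open, on these data alone, are whether a longer chain such as butylamino continues the trend on this core, and whether the propylamino group gives a step of similar direction and size on the core of compound 1.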